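A few compounds are considered here, and "the series" means these few. Any claim that something is new, unique, unknown or untested is made for them only; others in the source may bear on it.

Compound 1 `CN1CCC[C@H]1COc1cccnc1`: 1.9 nM
Compound 2 `CN1CCC[C@H]1COc1cncc(C#CCO)c1`: 0.93 nM
Compound 3 `CN1CCC[C@H]1COc1cncc(C#CCCCCO)c1`: 0.85 nM

These values come from an assay on a protein complex for binding affinity to Neuronal acetylcholine receptor; alpha4/beta2 (Rattus norvegicus); on this read-out lower numbers stand for stronger inhibition and higher numbers for weaker inhibition. Compound 3 has the lowest number of the three, but its gap to compound 2 is within the scatter, so the two cannot be ranked; only compound 1 stands clearly apart, a 2.2-fold lower number from compound 1 to compound 3 (0.35 log units; beyond the scatter). Compound 4 `CCCCC#Cc1cncc(OC[C@@H]2CCCN2C)c1` has not yet been measured; it differs from compound 3 in one place: hydrogen in place of hydroxy on a saturated chain carbon, four bonds along the chain from a triple-bonded carbon. Among the compounds with values here, no measured step removes a hydroxy outright. The nearest guide is a 1.1-fold lower number from compound 2 to compound 3 (0.04 log units; within the scatter), where changing the hydroxy-bearing chain altered nothing beyond the scatter, while a 2.0-fold lower number from compound 1 to compound 2 (0.31 log units; beyond the scatter) and a 2.2-fold lower number from compound 1 to compound 3 (0.35 log units; beyond the scatter) show that adding either alkyne chain lowered the number modestly. With the chain kept and only the hydroxy gone, compound 4 is expected to stay close, a 1.2-fold higher number from compound 3 to compound 4 (0.07 log units; within the scatter). Compound 4 is estimated at 1 nM, within 0.4 nM to 2.5 nM.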

Compound 4, inhibition constant: 1.4 nM
The estimate for compound 4 lay 1.4-fold (0.15 log units) below the measured number; low and high end bracket the measured number.
By their numbers in this assay, from the lowest: compounds 3, 2, 4 and 1 (each within the scatter of the next, the first and the last beyond it).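

Taking the hydroxy off the chain end leaves the number in this assay within the scatter (a 1.6-fold higher number from compound 3 to compound 4 (0.22 log units; within the scatter)), so this assay shows no clear need for that hydroxy. Compound 4 also cannot be separated from the shorter hydroxy compound (a 1.5-fold higher number from compound 2 to compound 4 (0.18 log units; within the scatter)). Unlike the two hydroxy chains, though, the plain hex-1-yn-1-yl chain no longer stands beyond the scatter from the unsubstituted compound (a 1.4-fold lower number from compound 1 to compound 4 (0.13 log units; within the scatter)). As far as these compounds go, whether an amine or a carboxylic acid at the chain end, or a longer chain, would move the number beyond the scatter stays open. No measurement shown offers an explanation for these results.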